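The source may report more compounds than this note shows. Statements on the series, on what has been measured and on what is new or still open speak of the compounds shown alone.

Of the compounds shown here, three have been tested in a functional assay on HeLa cells (Homo sapiens) for cytotoxicity, read by MTT assay, with a stated time of 72 h; a lower number here means a stronger inhibitor, a higher number a weaker inhibitor. Compound 1 `CC1=CC[C@]2(C)[C@@H]([C@@H](OC(=O)c3ccc(O)cc3)C1)[C@](O)(C(C)C)C[C@@H]2O` gives 56500 nM in this assay. Compound 2 `COc1ccc(C(=O)OCC2=CC[C@@]3(C)CC[C@]4(C(C)C)O[C@]34CC2)cc1` returns > 100000 nM in this assay, which is a limit of the assay rather than a number. Compound 3 `COc1ccc(C(=O)O[C@H]2CC(C)=CC[C@@]3(C)CC[C@@](O)(C(C)C)[C@H]23)cc1` likewise returns > 100000 nM in this assay, again a limit and not a number. Compound 3 therefore stands at the top edge of what this assay can report, and it is not alone there, since the limit of > 100000 nM in this assay, at which 2 of the 3 values shown sit, covers two of the three values given.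

Compound 4 `CC1=CC[C@@]2(C)CC[C@@](O)(C(C)C)[C@@H]2[C@@H](OC(=O)c2ccc(O)cc2)C1` has not yet been measured in this assay. It differs from compound 3 in one place: hydrogen in place of methyl on an oxygen on an aromatic ring. Put another way, a methoxy becomes a hydroxy, so a 4-methoxyphenyl ester becomes a 4-hydroxyphenyl ester. Going by the values given here, no pair of measured compounds differs in exactly this way, so the size of the step cannot be read from the data. Compound 1 carries the same 4-hydroxyphenyl ester on a differently arranged core and gives 56500 nM in this assay, which is only a loose pointer.

The step from compound 3 to compound 4 is expected to be an at least 1.2-fold lower number from compound 3 to compound 4 (0.09 log units; that floor lies within the scatter) in this assay. For compound 4 the estimated value in this assay is 80000 nM, with a likely range from 30000 nM to 200000 nM.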

Compound 4, half-maximal inhibitory concentration: > 100000 nM
Compound 4: no number, only a limit; the forecaster's own chance of this, stated with the estimate: 55%; middle value at least 1.2-fold (0.09 log units) from the limit.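

In this assay compound 4 returns > 100000 nM, which is a limit of the assay and not a number, and the top edge of the assay now holds most of the series: the limit of > 100000 nM in this assay, at which 3 of the 4 values shown sit. Since compound 3 sits at that same limit, the step for methoxy to hydroxy cannot be read, and all that can be said is that a 4-hydroxyphenyl ester in place of a 4-methoxyphenyl ester does not bring this core to a measurable value. The second comparison, hydrogen in place of hydroxy on a saturated ring carbon, gives an at least 1.7-fold higher number from compound 1 to compound 4 (0.24 log units; that floor lies within the scatter), so the only firm statement about that hydroxy is a floor that does not clear the usual scatter, and it cannot show that the hydroxy matters.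

Going by these compounds, the true size of both changes stays open, since a limit hides how far each compound lies beyond it. Also open, on these data alone, is whether an amine or a carboxylic acid on the aromatic ring, in place of the hydroxy, would give a value that can be read on this core.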